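Removing 4-methoxybenzyl from compound 3

The source may hold more compounds than are shown below. What is called first, only, known or untested is meant among the compounds shown, and "the series" means these compounds.

Values in a functional assay on A375P cells (Homo sapiens) for inhibition, read by MTT assay, with a stated time of 24 h (on this read-out higher numbers stand for weaker inhibition of growth and lower numbers for stronger inhibition of growth), so far:
- compound 1 `O=C1CC(c2cccc(NC(=O)Nc3ccc(Cl)cc3)c2)=Nc2cn[nH]c2N1` gives > 30000 nM as a limit
- compound 2 `COc1ccc(Cn2ncc3c2NC(=O)CC(c2cccc(NC(=O)Nc4cc(Cl)cc(Cl)c4)c2)=N3)cc1` gives 780 nM as a number
- compound 3 `COc1ccc(Cn2ncc3c2NC(=O)CC(c2cccc(NC(=O)Nc4ccc(Cl)c(Cl)c4)c2)=N3)cc1` gives 3860 nM as a number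

Compound 3 holds the higher of the two numbers. For the measured compounds named here, the one measured step is a 4.9-fold higher number from compound 2 to compound 3 (0.69 log units; beyond the scatter) and concerns the dichlorophenyl pattern, not the change at hand. Compound 4 `O=C1CC(c2cccc(NC(=O)Nc3ccc(Cl)c(Cl)c3)c2)=Nc2cn[nH]c2N1` differs by hydrogen in place of 4-methoxybenzyl on an aromatic nitrogen with hydrogen in place of 4-methoxybenzyl on an aromatic nitrogen. Going by the values given here, no measured step covers this change directly. Compound 1 also carries hydrogen on that nitrogen, and > 30000 nM is its limit in this assay and so a large step to a higher number is expected. The expected step is a 5.7-fold higher number from compound 3 to compound 4 (0.76 log units; beyond the scatter) and the assay may report only a limit. Compound 4 is estimated at 22000 nM with a range from 7000 nM to 60000 nM expected.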

Compound 4, concentration for 50% growth inhibition: > 30000 nM
Compound 4 gave a limit, no number; the forecaster's own chance of this, stated with the estimate: 55%; at least 1.3-fold (0.13 log units) between middle value and limit.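

In this assay, hydrogen in place of 4-methoxybenzyl on the aromatic nitrogen gives an at least 7.7-fold higher number from compound 3 to compound 4 (0.89 log units; beyond the scatter), the only direct reading of this change among the compounds shown. With 4-methoxybenzyl on that nitrogen, growth inhibition gives a number, while both compounds with hydrogen there give only a limit. The step between compound 1 and compound 4 cannot be read, and the size of the loss has no upper bound: the limit of > 30000 nM in this assay, at which 2 of the 4 values shown sit.

As far as these compounds go, whether methyl, plain benzyl or a longer chain ending in an amine on that nitrogen would give a number stays open. So does the size of this change with the 3,5-dichlorophenyl of compound 2.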